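A Second Chloro on the Shared Core: Compound 1 to Compound 4

The source may report more compounds than this note shows. Statements on the series, on what has been measured and on what is new or still open speak of the compounds shown alone.

Compound 1 `ClCc1ccc(Cn2cnc3c(Cl)ncnc32)cc1` serves as the reference point. In a functional assay on OVCAR-4 cells (Homo sapiens) for cytotoxicity, read by sulforhodamine B assay, with a stated time of 48 h (a lower number here means a stronger inhibitor of growth, a higher number a weaker inhibitor of growth), compound 1 gives 6600 nM. Two related compounds have been measured alongside it: compound 2 `ClCc1cccc(Cn2cnc3c(Cl)ncnc32)c1` gives 5750 nM in this assay, and compound 3 `ClCc1ccc(Cn2cnc3nc(Cl)nc(Cl)c32)cc1` gives 4160 nM. None of these three numbers is separated from another by more than the usual scatter, so compound 1 stands together with compound 2 and compound 3 rather than apart from them, and no ordering among the three can be read from the data.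

The step to compound 4 `ClCc1ccc(Cn2cnc3c(Cl)nc(Cl)nc32)cc1` is a single change on the shared core: chloro in place of hydrogen on an aromatic carbon. For the measured compounds named here, no measured pair isolates this exact change, so the expectation leans on what the three measured values show, all of them sitting close together. Compound 4 is therefore expected to land near its neighbours, with a step from compound 1 to compound 4 of a 1.4-fold lower number from compound 1 to compound 4 (0.14 log units; within the scatter) in this assay, not clearly beyond the scatter. The value of compound 4 in this assay is estimated at 4800 nM, within a range of 2000 nM to 11000 nM.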

Compound 4, concentration for total growth inhibition: 18600 nM
Compound 4: middle estimate off by 3.9-fold (0.59 log units), on the low side; measured number outside the range, above it.
By their numbers in this assay, from the lowest: compounds 3, 2 and 1 (each within the scatter of the next); then compound 4.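

In this assay, chloro in place of hydrogen on an aromatic carbon, between two ring nitrogen atoms, gives a 2.8-fold higher number from compound 1 to compound 4 (0.45 log units; beyond the scatter). For the compounds shown here, this is the first step in the set to lie beyond the scatter: the three earlier compounds showed no ordering, whereas compound 4 is a weaker inhibitor of growth than compound 1, so this position of the shared core is not indifferent to the change. Nothing available explains why the number rises at this position.

The compounds shown carry only hydrogen or chloro at this carbon, so whether an amine, a methoxy group or a methyl group there would behave like chloro remains open. Also open, from the compounds shown here alone, is whether the same change would raise the number when made on compound 2.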